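A Larger Ether Side Chain on a Shared Core

The source may report more compounds than this note shows. Statements on the series, on what has been measured and on what is new or still open speak of the compounds shown alone.

Three compounds built on one core were tested in a functional assay on PANC-1 cells (Homo sapiens) for inhibition, read by MTT assay, with a stated time of 24 h, tested at 10 uM; on this read-out lower numbers stand for less inhibition and higher numbers for more inhibition at the one concentration tested (going by the name of the read-out). Compound 1 `CC(C)=CCC/C(C)=C/CC1Cc2c(O)cc(=O)n(CCCO)c2CC1(C)C` gives 28.7%, compound 3 `CC(C)=CCC1Cc2c(OCCCNS(=O)(=O)c3ccc(C(F)(F)F)cc3)cc(=O)n(CCCO)c2CC1(C)C` gives 29.6%, and compound 2 `CC(C)=CCOc1cc(=O)n(CCCO)c2c1CC(CC=C(C)C)C(C)(C)C2` gives 20.7%. Compound 2 holds the lowest of the three numbers, yet its gaps to compound 1 and to compound 3 both lie within the scatter, so the three read as alike. Compound 4 `COc1ccc(OCCCOc2cc(=O)n(CCCO)c3c2CC(CC=C(C)C)C(C)(C)C3)cc1` is not yet measured; it differs from compound 2 by 2-(4-methoxyphenoxy)ethyl in place of 2-methylprop-1-en-1-yl on a saturated chain carbon bound to an oxygen on an aromatic ring. Going by the values given here, no measured pair here isolates a single change, so nothing anchors the size of this step; given the narrow spread of the measured numbers, a step no larger than the scatter in either direction is expected, as a number 6.3 percentage points higher from compound 2 to compound 4 (within the scatter). Compound 4 is therefore expected to give 27% in this assay, within 12% to 45%.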

Compound 4, a percentage reported as inhibition, at one concentration (the size of the read-out at that concentration, not a potency): 47.7%
Estimate against measurement, compound 4: 20.7 percentage points below, and the stated range ends below it.
By their numbers in this assay, from the lowest: compounds 2, 1 and 3 (each within the scatter of the next); then compound 4.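

Putting 2-(4-methoxyphenoxy)ethyl in place of 2-methylprop-1-en-1-yl on a saturated chain carbon bound to an oxygen on an aromatic ring gives, in this assay, a number 27 percentage points higher from compound 2 to compound 4 (beyond the scatter). This shows that the number responds to what this position carries, which the three earlier compounds, all alike within the scatter, could not show. Nothing measured here explains the step. The compounds shown leave open whether the aromatic ring, its methoxy group or the ether oxygen carries the step. They also leave open what a terminal amine or carboxylic acid on this chain would give.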